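The source may hold more compounds than are shown below. What is called first, only, known or untested is meant among the compounds shown, and "the series" means these compounds.

Series of sulfonyl-bearing compounds sharing one core, examined for cytotoxicity in a functional assay on Huh-7 cells (Homo sapiens) for cytotoxicity, read by sulforhodamine B assay, with a stated time of 72 h; on this read-out lower numbers stand for stronger inhibition and higher numbers for weaker inhibition. Compound 1 `Cc1ccc(S(=O)(=O)n2cnc3c(Cl)ncnc32)cc1` gives 20800 nM in this assay. Compound 2 `Cc1ccc(S(=O)(=O)n2cnc3c(N4CCC(C)CC4)ncnc32)cc1` gives 17800 nM. For the measured compounds named here, the single one-place step, a 1.2-fold lower number from compound 1 to compound 2 (0.07 log units; within the scatter), lies within the scatter. Going by the values given here, compound 3 `Cc1ccc(S(=O)(=O)n2cnc3c(NCc4ccc(Cl)cc4Cl)ncnc32)cc1` gives 26900 nM in this assay; its value lies within the scatter of both compound 1 and compound 2, so no compound among the three can be set apart from the others.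

Compound 4 `Cc1ccc(S(=O)(=O)n2cnc3c(NCCC4C=CCCC4)ncnc32)cc1` differs from compound 3 by (cyclohex-2-en-1-yl)methyl in place of 2,4-dichlorophenyl on a saturated chain carbon bound to a nitrogen on an aromatic ring. Among the compounds with values here, no measured step touches this part of the molecule: the only step on record, a 1.2-fold lower number from compound 1 to compound 2 (0.07 log units; within the scatter), concerns the aromatic carbon bearing chloro, and it was within the scatter. With the three measured values clustered together and no comparable change available, no step beyond the scatter is expected in this assay. Compound 4 is therefore estimated at 25000 nM, with a range of 10000 nM to 60000 nM, which corresponds to an expected step of a 1.1-fold lower number from compound 3 to compound 4 (0.03 log units; within the scatter).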

Compound 4, half-maximal inhibitory concentration: 9400 nM
Estimate against measurement, compound 4: 2.7-fold (0.42 log units) above; the measured number lies below the stated range.
By their numbers in this assay, from the lowest: compounds 4, 2, 1 and 3 (each within the scatter of the next, the first and the last beyond it).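

In this assay, for the compounds shown here, replacing 2,4-dichlorophenyl with (cyclohex-2-en-1-yl)methyl on a saturated chain carbon bound to a nitrogen on an aromatic ring gives the first step beyond the scatter, a 2.9-fold lower number from compound 3 to compound 4 (0.46 log units; beyond the scatter), so this position does register a change, though only a modest one. The (2-(cyclohex-2-en-1-yl)ethyl)amino group in place of chloro is also a modest step beyond the scatter, a 2.2-fold lower number from compound 1 to compound 4 (0.34 log units; beyond the scatter), whereas in place of 4-methylpiperidin-1-yl it stays within the scatter, a 1.9-fold lower number from compound 2 to compound 4 (0.28 log units; within the scatter), so compound 4 cannot be set apart from compound 2. No available evidence bears on what lies behind these differences.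

On these data alone, it remains open whether the step at this position tracks the loss of the two chlorines, the non-aromatic ring or its double bond. A plain benzyl group or a saturated 2-cyclohexylethyl group in this place would help to separate these.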